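Fluoro for Methyl on a Shared Core: Expected Response

This account rests on a few compounds, and the source may have more. Where it says the series, first, only, none or still open, it means among the compounds named here.

Measured so far:
compound 1, `Fc1ccc(-c2noc3c2CCNCC3)cc1`: 98%
compound 2, `Cc1ccc(-c2n[nH]c3c2CCNCC3)cc1`: 97.4%

Of the compounds shown here, two have been measured in a functional assay on HEK293 cells for antagonist activity at 5-hydroxytryptamine receptor 7 (Homo sapiens), read by luminescence and cAMP accumulation; on this read-out higher numbers stand for larger maximal responses and lower numbers for smaller maximal responses. Compound 1 reaches 98%, and compound 2 reaches 97.4%. The two numbers lie within the scatter of each other, so compound 2 stands level with compound 1 on what has been seen; nothing separates them in this assay.

The next compound, compound 3 `Fc1ccc(-c2n[nH]c3c2CCNCC3)cc1`, has not yet been measured. It differs from compound 2 in one place: fluoro in place of methyl on an aromatic carbon. Within the data shown here, no step between measured compounds is available for this kind of change, so the expectation rests on the two values alone.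

Both measured compounds give near-complete maximal responses in this assay, and a single change of one heavy atom on the aromatic ring of carbon gives no reason on these numbers to expect a departure. The step from compound 2 to compound 3 is expected to be a number 0.6 percentage points higher from compound 2 to compound 3 (within the scatter), that is, none beyond the scatter. For compound 3 the estimated value in this assay is 98%, with a range from 88% to 106%.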

Compound 3, largest response reached (reported as Imax), in percent of the reference or control that the assay uses: 98.4%
Beside the measured number, compound 3's estimate is 0.4 percentage points below it, and the stated range covers the measured number.
By their numbers in this assay, from the lowest: compounds 2, 1 and 3 (each within the scatter of the next).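

Among these compounds, compound 2 and compound 3 form the first pair here that differs in one place only, which makes it possible to look at this position on its own; compound 1 and compound 2 differ in more than one place. In this assay, putting fluoro in place of methyl on an aromatic carbon, para to a large group, gives a number 1 percentage points higher from compound 2 to compound 3 (within the scatter). This position therefore accepts either of these two single-atom groups without a detectable change in maximal response, although this one pair cannot show how the position treats other groups, and no further measurement is available here to explain the result.

Going by these compounds, the two groups compared each have just one heavy atom, so it remains open whether a larger or quite different group at the same place, such as a longer chain, an amine or a carboxylic acid, would leave the response at this level. A maximal response also gives no information on the concentration needed to reach it, so whether methyl and fluoro differ on that separate scale remains an open question.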